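A Smaller Sulfonyl Group and the Question of Solubility

A few compounds are considered here, and "the series" means these few. Any claim that something is new, unique, unknown or untested is made for them only; others in the source may bear on it.

Among the compounds with values here, compound 1 `O=S(=O)(c1cccc(-c2ccc3nccc(-c4ccncc4)c3n2)c1)N1CCC(O)CC1` is the only member of this small set with a measured number: in a physicochemical assay for solubility, read by HPLC, using the shake flask method, measured as kinetic solubility, with a stated time of 20 h, at pH 6.5, tested at 200 uM (on this read-out higher numbers stand for higher solubility and lower numbers for lower solubility), compound 1 gives 10000 nM. Compound 2 `O=S(=O)(NCCO)c1cccc(-c2ccc3nccc(-c4ccc(OC(F)(F)F)cc4)c3n2)c1` reaches only a limit of the assay rather than a number, as compound 2 gives < 5000 nM in this assay. Compound 3 `O=S(=O)(NCc1ccccc1)c1cccc(Nc2ccc3nccc(-c4ccncc4)c3n2)c1` likewise sits at a limit, with compound 3 giving < 5000 nM in this assay. Within the data shown here, two of the three values therefore rest at the limit of < 5000 nM in this assay, at which 2 of the 3 values shown sit, and compound 1 stands as the one compound with a number above that point.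

Compound 4 `CS(=O)(=O)Nc1cccc(-c2ccc3nccc(-c4ccncc4)c3n2)c1` has not yet been measured. It differs from compound 1 in one place: methanesulfonamido in place of (4-hydroxypiperidin-1-yl)sulfonyl on an aromatic carbon. Among the measured compounds shown here, no step between two measured compounds is available to calibrate such a change, so the expectation rests on compound 1 alone. The step expected here is a 2.0-fold lower number from compound 1 to compound 4 (0.30 log units; within the scatter), a modest move downward. Compound 4 is thus estimated at 5000 nM in this assay. The range expected for compound 4 runs from 1500 nM to 15000 nM. A limit rather than a number is a real possibility for compound 4.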

Compound 4, solubility: 20000 nM
The estimate for compound 4 lay 4.0-fold (0.60 log units) below the measured number; the measured number lies above the stated range.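

In this assay, replacing (4-hydroxypiperidin-1-yl)sulfonyl with methanesulfonamido on this aromatic carbon gives a 2.0-fold higher number from compound 1 to compound 4 (0.30 log units; within the scatter). Within the data shown here, this is the first step in the set, and it shows that the read-out can stay level within the scatter when the six-membered non-aromatic ring and its hydroxyl group are gone and the group shrinks to the small, ring-free methanesulfonamido. Compound 4 also gives a true number, whereas other values in the set remain limits of the assay and not numbers: the limit of < 5000 nM in this assay, at which 2 of the 4 values shown sit.

Going by these compounds, whether this tolerance extends to other groups on the same aromatic carbon, such as a carboxylic acid, a basic amine or a longer chain like butanesulfonamido, remains open. One step also cannot show whether the same exchange would read the same way with a different group elsewhere on the shared core.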